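Swapping the aryl group on two related cores

This account rests on a few compounds, and the source may have more. Where it says the series, first, only, none or still open, it means among the compounds named here.

Four compounds share a common amide-linked scaffold. Compound 1, `COc1cccc(-c2cc(C(=O)Nc3ccc(Oc4ccnc5cc(OCCCN6CCCC6)c(OC)cc45)c(F)c3)c3ccccc3n2)c1`, and compound 2, `COc1cc2c(Oc3ccc(NC(=O)c4cc(-c5ccc(C)cc5)nc5ccccc45)cc3F)ccnc2cc1OCCCN1CCCC1`, differ in one place only: 4-methylphenyl in place of 3-methoxyphenyl on an aromatic carbon. In a functional assay on HT-29 cells (Homo sapiens) for cytotoxicity, read by MTT assay, with a stated time of 72 h (on this read-out lower numbers stand for stronger inhibition and higher numbers for weaker inhibition), compound 1 gives 1020 nM, and compound 2 gives 850 nM, so the change made a 1.2-fold lower number from compound 1 to compound 2 (0.08 log units; within the scatter). These two numbers cannot be told apart.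

Compound 3, `COc1cccc(-c2cc(C(=O)Nc3ccc(Oc4ccnc5cc(OCCCN6CCCCC6)c(OC)cc45)c(F)c3)c3cc(F)ccc3n2)c1`, carries the same 3-methoxyphenyl as compound 1 but on a different core; how the two cores differ is not broken down here. In this assay compound 3 gives 2500 nM, the highest of the three numbers measured.

Compound 4, `COc1cc2c(Oc3ccc(NC(=O)c4cc(-c5ccc(C)cc5)nc5ccc(F)cc45)cc3F)ccnc2cc1OCCCN1CCCCC1`, has not been measured yet. It stands to compound 3 exactly as compound 2 stands to compound 1, since the change is 4-methylphenyl in place of 3-methoxyphenyl on an aromatic carbon, the same change made at the same place. Among the compounds with values here, the only guide to what it will do is the single pair already measured, where the step from compound 1 to compound 2 fell inside the usual spread of repeats. On that basis compound 4 is expected to land close to compound 3, with a step estimated as a 1.2-fold lower number from compound 3 to compound 4 (0.08 log units; within the scatter). Compound 4 is therefore estimated at 2100 nM in this assay, most likely somewhere between 1000 nM and 4500 nM, with the wide range reflecting that a single measured pair is the whole of the evidence.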

Compound 4, half-maximal inhibitory concentration: 500 nM
Compound 4: middle estimate off by 4.2-fold (0.62 log units), on the high side, and the stated range ends above it.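

On the core of compound 3, the swap of 3-methoxyphenyl for 4-methylphenyl on the aromatic carbon next to the ring nitrogen made a 5.0-fold lower number from compound 3 to compound 4 (0.70 log units; beyond the scatter) in this assay, a step that stands clear of the scatter. The same change therefore does not have the same size on both cores, and the step measured on one core could not be carried over to the other as it stood: the same change on two cores in this assay, a 1.2-fold lower number (0.08 log units; within the scatter) from compound 1 to compound 2 and a 5.0-fold lower number (0.70 log units; beyond the scatter) from compound 3 to compound 4, 4.2-fold (0.62 log units) apart, beyond the scatter of two such steps

Within the data shown here, with only two pairs in a single cell assay, this does not show which of the features separating the two cores accounts for the gap, nor how large the step would be on any further core.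

The compounds shown leave open whether the lower number seen on the second core depends on the 4-methylphenyl group itself or on the loss of 3-methoxyphenyl, which an unsubstituted phenyl group at the same place would help to separate. They also leave open how other aryl groups, such as a chlorophenyl or a pyridyl ring, would behave at this place on either core.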